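Swapping chloro for iodo on two related nucleoside cores

The compounds below may be only part of what the source reports. "The series", "measured", "known", "first", "only" and "open" are said of these compounds alone.

Three compounds have been measured in a functional assay on HeLa cells (Homo sapiens) for antiproliferative activity, read by cell counting, with a stated time of 72 h; on this read-out lower numbers stand for stronger inhibition and higher numbers for weaker inhibition:

Compound 1, `C#C[C@@]1(O)[C@@H](CO)O[C@@H](n2cc(Cl)c3c(N)ncnc32)[C@@H]1O`, gives 51 nM.
Compound 2, `C#C[C@@]1(O)[C@@H](CO)O[C@@H](n2cc(I)c3c(N)ncnc32)[C@@H]1O`, gives 180 nM.
Compound 3, `C#C[C@@]1(O)[C@@H](CO)O[C@@H](n2cc(Cl)c3c(N)ccnc32)[C@@H]1O`, gives 1700 nM.

Compounds 1 and 2 share one core and differ only in iodo in place of chloro on an aromatic carbon. That single change moved the read-out by a 3.5-fold higher number from compound 1 to compound 2 (0.55 log units; beyond the scatter), so compound 2 inhibits growth less strongly than compound 1.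

Compound 3 carries the same chloro group on a different core; how the two cores differ is not broken down here. Its number is the highest of the three, far beyond the scatter from both compound 1 and compound 2.

Compound 4, `C#C[C@@]1(O)[C@@H](CO)O[C@@H](n2cc(I)c3c(N)ccnc32)[C@@H]1O`, has not yet been measured. It differs from compound 3 by iodo in place of chloro on an aromatic carbon, the same change, at the same place, that turned compound 1 into compound 2. If the core of compound 3 responds to this change as the core of compound 1 did, the number should rise again by a modest amount. Nothing is known about whether the two cores respond alike, so the expected range is kept wide.

Compound 4 is therefore expected to give 5000 nM in this assay, between 1700 nM and 15000 nM. The expected step is a 2.9-fold higher number from compound 3 to compound 4 (0.47 log units; beyond the scatter), resting on the measured step of a 3.5-fold higher number from compound 1 to compound 2 (0.55 log units; beyond the scatter).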

Compound 4, half-maximal inhibitory concentration: 180 nM
Compound 4: middle estimate off by 28-fold (1.44 log units), on the high side, outside the stated range (below it).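

In this assay, putting iodo in place of chloro on the core of compound 3 gave a 9.4-fold lower number from compound 3 to compound 4 (0.98 log units; beyond the scatter), so on this core iodo goes with stronger inhibition of growth, whereas on the core of compound 1 it went with weaker inhibition. Set side by side, the two steps run in opposite directions, and the gap between them is too large to put down to ordinary variation between repeated measurements: the same change on two cores in this assay, a 3.5-fold higher number (0.55 log units; beyond the scatter) from compound 1 to compound 2 and a 9.4-fold lower number (0.98 log units; beyond the scatter) from compound 3 to compound 4, 33-fold (1.52 log units) apart, beyond the scatter of two such steps

This shows that, across these two pairs, a step measured on one core cannot simply be carried over to the other, since even its direction changed; it does not show why the cores respond differently, or how any further core would respond to the same swap.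

Among the compounds shown, only chloro and iodo sit at this place, so it remains open whether a bromo group, a methyl group or a nitrile would also shift the number in opposite directions on the two cores. From the compounds shown here alone, it is also open whether the same reversal would appear in cell types other than the one used here.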